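The source may report more compounds than this note shows. Statements on the series, on what has been measured and on what is new or still open speak of the compounds shown alone.

Working notes on the amino-ester series. Compound 1 `CC(C)[C@H](N)C(=O)OC1CCN(S(=O)(=O)c2cc(C(=O)Nc3cc(F)c(F)c(F)c3)ccc2F)CC1` and compound 2 `CCC(C)[C@H](N)C(=O)OC1CCN(S(=O)(=O)c2cc(C(=O)Nc3cc(F)c(F)c(F)c3)ccc2F)CC1` share the same core and differ only in the alkyl side chain of the amino-ester. In an ADME assay on HepG2 2.2.15 cells (Homo sapiens) for cytotoxicity (a lower number here means that less compound is tolerated, a higher number that more compound is tolerated), compound 1 gives a value that is a limit of the assay, > 10000 nM. In this assay compound 2 likewise reaches only a limit, > 10000 nM. The step that the two limits leave unreadable from compound 1 to compound 2 is therefore of unreadable size, because both values sit at the limit of > 10000 nM in this assay, at which 2 of the 2 values shown sit. Where compound 2 stands is known only as a limit, not as a number.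

Compound 3 `CC(C)(C)[C@H](N)C(=O)OC1CCN(S(=O)(=O)c2cc(C(=O)Nc3cc(F)c(F)c(F)c3)ccc2F)CC1` is the next member: tert-butyl in place of sec-butyl on a saturated chain carbon bound to an amine nitrogen and a carbonyl carbon. Within the data shown here, the one measured step, a step that the two limits leave unreadable from compound 1 to compound 2, bears on this change as an alkyl variation on the same carbon, and it gave no readable size. Among the measured compounds shown here, no step in this assay beyond the scatter is therefore expected, with a step that the limit leaves unreadable from compound 2 to compound 3 estimated as flat. Compound 3 is expected to give 15000 nM in this assay, with the estimated range running from 5000 nM to 50000 nM, and most likely to be reported again only as a limit.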

Compound 3, half-maximal cytotoxic concentration: > 10000 nM
Compound 3 ended at the assay's limit; the forecaster's own chance of this, stated with the estimate: 85%; the middle value does not contradict the limit.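

No step among compound 1, compound 2 and compound 3 can be read in this assay, because all three values are limits of the assay: the limit of > 10000 nM in this assay, at which 3 of the 3 values shown sit.

The compounds shown leave open where the half-maximal cytotoxic concentration of each actually lies, and whether the alkyl side chain of the amino-ester has any bearing on it in this assay.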